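The source may report more compounds than this note shows. Statements on the series, on what has been measured and on what is new or still open speak of the compounds shown alone.

Measured compounds in a physicochemical assay for lipophilicity, in phosphate buffer, measured as octanol-water partition, with a stated time of 24 h; on this read-out higher numbers stand for higher lipophilicity and lower numbers for lower lipophilicity:
- compound 1 `Cc1cc(Oc2ccc(/C=N/NC(=S)Nc3ccc(F)cc3)cc2)ccc1Cl`: 6.07
- compound 2 `Cc1ccc(Oc2ccc(/C=N/NC(=S)Nc3ccc(F)cc3)cc2)cc1`: 5.48
- compound 3 `Fc1ccc(NC(=S)N/N=C/c2ccc(Oc3ccc4ccccc4c3)cc2)cc1`: 6.2

Compound 3 stands highest of the three numbers. Its nearest neighbour is compound 1, at a step of a number 0.13 log units higher from compound 1 to compound 3 (within the scatter), which is within the scatter; its furthest is compound 2, at a step of a number 0.72 log units higher from compound 2 to compound 3 (beyond the scatter), which is beyond it. The step of a number 0.59 log units lower from compound 1 to compound 2 (beyond the scatter) separates the two aryl ethers that carry a single ring.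

Compound 4 `Fc1ccc(NC(=S)N/N=C/c2ccc(Oc3ccc(Cl)cc3)cc2)cc1` is not yet measured. It differs from compound 3 in one place: 4-chlorophenyl in place of naphthalen-2-yl on an oxygen on an aromatic ring. Both steps that bear on this change replace a single carbocyclic ring with naphthalen-2-yl: the step of a number 0.13 log units higher from compound 1 to compound 3 (within the scatter) and the step of a number 0.72 log units higher from compound 2 to compound 3 (beyond the scatter). Taking that change in the reverse direction, a modest fall is expected for compound 4, estimated as a number 0.50 log units lower from compound 3 to compound 4 (beyond the scatter), because compound 1 gives 6.07 with 4-chloro-3-methylphenyl and compound 2 gives 5.48 with 4-methylphenyl, and the 4-chlorophenyl of compound 4 is likewise a single carbocyclic ring, carrying the chlorine of the former and a single substituent like the latter. Compound 4 is therefore expected at 5.7, in a range from 5.3 to 6.1.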

Compound 4, partition coefficient: 5.78
The estimate for compound 4 lay 0.08 log units below the measured number, within the range that was stated.
By their numbers in this assay, from the lowest: compounds 2, 4, 1 and 3 (each within the scatter of the next, the first and the last beyond it).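

In this assay, 4-chlorophenyl in place of naphthalen-2-yl on an oxygen on an aromatic ring gives a number 0.42 log units lower from compound 3 to compound 4 (beyond the scatter) and so opens a gap that the 4-chloro-3-methylphenyl of compound 1 did not show against the naphthalen-2-yl group. Compound 4 also stands within the scatter of both single-ring neighbours, which lie beyond the scatter of each other: chloro in place of methyl on an aromatic carbon gives a number 0.30 log units higher from compound 2 to compound 4 (within the scatter) and hydrogen in place of methyl on an aromatic carbon gives a number 0.29 log units lower from compound 1 to compound 4 (within the scatter) and neither exchange is resolved on its own. Nothing shown accounts for these steps.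

The compounds shown leave open how the read-out would respond to an amine or a carboxylic acid on the ring attached to the oxygen. They also leave open whether a longer chain in place of the chloro group would separate from compound 4.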